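The source may hold more compounds than are shown below. What is called first, only, known or untested is meant among the compounds shown, and "the series" means these compounds.

In a functional assay on U-251 cells (Homo sapiens) for inhibition, read by sulforhodamine B assay, with a stated time of 48 h (a higher number here means a weaker inhibitor of growth, a lower number a stronger inhibitor of growth), three compounds have been measured. Compound 1, `COc1cc(C)cc(-c2c(-c3ccnc(-c4ccc(C(C)=O)cc4)c3)cnn2CC#N)c1`, gives > 100000 nM, which is a limit of the assay and not a number; (the limit of > 100000 nM in this assay, at which 1 of the 3 values shown sits). Compound 2, `COc1cc(C)cc(-c2nn(CC#N)cc2-c2ccc(-c3cccc(C(C)=O)c3)nc2)c1`, gives 13500 nM. Compound 3, `Cc1cc(O)cc(-c2nn(CC#N)cc2-c2ccnc(-c3ccc(Oc4ccccc4)cc3)c2)c1`, gives 2990 nM, the lowest of the two numbers, and its gap to compound 2 lies beyond the usual scatter of repeated measurements, so compound 3 is the stronger growth inhibitor of those two. All three share the same core, with a nitrile-bearing chain on the pyrazole nitrogen, and differ in the groups on the two outer aromatic rings.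

The next compound, compound 4, `Cc1cc(O)cc(-c2nn(CC#N)cc2-c2ccnc(-c3ccc(N(C)C)cc3)c2)c1`, differs from compound 3 in one place: dimethylamino in place of phenoxy on an aromatic carbon. Within the data shown here, no measured pair of compounds shows a change of this kind, so the size of its effect cannot be read from what is known. As far as these compounds go, the phenoxy group is large and the dimethylamino group small, but how that matters for growth inhibition here is untested. A step from compound 3 to compound 4 of no more than the scatter, or a modest weakening, is expected, a 1.7-fold higher number from compound 3 to compound 4 (0.22 log units; within the scatter). Compound 4 is thus estimated at 5000 nM, with a likely range from 1200 nM to 20000 nM.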

Compound 4, concentration for total growth inhibition: 12900 nM
Compound 4: the middle estimate sits 2.6-fold (0.41 log units) below what was measured, and the stated range covers the measured number.
By their numbers in this assay, from the lowest: compound 3; then compounds 4 and 2 (each within the scatter of the next). At a limit, above all of these: compound 1.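

In this assay, among these compounds, the change at this aromatic carbon, para to a large group, gives a 4.3-fold higher number from compound 3 to compound 4 (0.63 log units; beyond the scatter), and it is the first step here in which only one place differs. It shows that this position is not indifferent to what it carries: with the rest of the molecule held constant, phenoxy, with its six-membered aromatic ring of carbon only, gives the lower number, while dimethylamino, with fewer heavy atoms and no ring, gives the higher one. The two groups have the same counts of hydrogen-bond donors and acceptors, so those counts do not separate them, and no measurement shown explains why the number rises.

As far as these compounds go, with only these two groups compared at this position, it remains open whether the ring, the overall size of the group or the atom joined to the aromatic carbon matters most; a methoxy group, a benzyl group or a simple phenyl ring could help separate these. This single step also leaves open whether the same swap would give a similar change with different groups on the other outer ring.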